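The source may report more compounds than this note shows. Statements on the series, on what has been measured and on what is new or still open speak of the compounds shown alone.

Three compounds of this series have been run in a functional assay on the whole organism for inhibition, with Rattus norvegicus as the target, read by paw edema, with stated times of 1 h and 6 h, at a dose of 10 umol/kg by the subcutaneous route; a higher number here means more inhibition at the dose given (going by the name of the read-out), a lower number less inhibition. Compound 1 `N#Cc1cnn(-c2ccc(S(N)(=O)=O)cc2)c1NC(=O)CCl` gives 46.1% in this assay. Compound 2 `CC(=O)Nc1c(C#N)cnn1-c1ccc(S(=O)(=O)NC(C)=O)cc1` gives 44.3% in this assay. Compound 3 `N#Cc1cnn(-c2ccc(S(N)(=O)=O)cc2)c1/N=C/c1ccc(F)cc1` gives 43% in this assay, the lowest of the three numbers, although its gap to compound 2 and its gap to compound 1 both lie within the scatter of repeated runs, so no ranking of the three can be read from these figures. Going by the values given here, no pair among the measured compounds differs in a single place, so no single-change step is available within the measured set.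

Compound 4 `COc1ccc(/C=N/c2c(C#N)cnn2-c2ccc(S(N)(=O)=O)cc2)cc1` has not yet been run. It differs from compound 3 in one place: methoxy in place of fluoro on an aromatic carbon. Cut one bond further out, the exchange reads 4-fluorophenyl to 4-methoxyphenyl. Among the compounds with values here, nothing measured so far shows how this exchange moves the read-out in this assay, and the three measured numbers sit close together despite larger differences among their structures, so there is no basis for expecting a large move.

Compound 4 is expected to give about 43% in this assay, with a range from 33% to 53%. The step from compound 3 to compound 4 is estimated at no change at the digits printed from compound 3 to compound 4 (within the scatter), which is no change beyond the scatter.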

Compound 4, a percentage reported as inhibition, in the whole organism at one dose (the size of the read-out at that dose, not a potency): 42.3%
For compound 4 the middle estimate is 0.7 percentage points above the measured one; the measured number falls inside the stated range.
By their numbers in this assay, from the lowest: compounds 4, 3, 2 and 1 (each within the scatter of the next).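

In this assay, the exchange of 4-fluorophenyl to 4-methoxyphenyl gives a number 0.7 percentage points lower from compound 3 to compound 4 (within the scatter), the first single-change step available in this series. On this aromatic carbon, para to a large group, the read-out therefore does not separate fluoro from methoxy at the dose given, even with 2 heavy atoms in place of 1 and a hydrogen-bond acceptor entering. No data bearing on the reason for this result are available.

Going by these compounds alone, a single pair at one dose leaves open whether this position influences the read-out at all, since fluoro and methoxy are the only two groups compared here and a percentage at one dose is not a potency. An amine or a carboxylic acid on the same aromatic carbon, or a longer chain such as butoxy in place of methoxy, would test whether the read-out stays this flat with groups further from these two.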